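The source may report more compounds than this note shows. Statements on the series, on what has been measured and on what is new or still open speak of the compounds shown alone.

Measured compounds:
compound 1 `O=C(NC1CC1)c1ccc(-c2cnn3c(NCC4CCOCC4)nc(NC4CCCC4)nc23)cc1` — 1700 nM
compound 2 `O=C(NC1CC1)c1ccc(-c2cnn3c(NCC4CCOCC4)nc(NC4CCCC4)nc23)cc1F` — 1700 nM

Both were tested in a functional assay on OVCAR-3 cells (Homo sapiens) for antiproliferative activity; on this read-out lower numbers stand for stronger inhibition of growth and higher numbers for weaker inhibition of growth. Compound 1 gives 1700 nM in this assay, and compound 2, which carries a fluoro in place of a hydrogen on an aromatic carbon, gives 1700 nM. Among the compounds with values here, the step of no change at the digits printed from compound 1 to compound 2 (within the scatter) shows that this change made no difference beyond the scatter, so compound 1 stands level with its only measured neighbour.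

Compound 3 `O=C(NC1CC1)c1ccc(-c2cnn3c(NCC4CCOCC4)nc(Oc4ccccc4)nc23)cc1` has not yet been measured. It differs from compound 1 in one place: phenoxy in place of cyclopentylamino on an aromatic carbon. The change sits on an aromatic carbon of the shared core, between two ring nitrogen atoms. Within the data shown here, no measured step involves this position or either of these groups; the single step on record concerns a fluoro at another aromatic carbon and says nothing about the size or direction of this change. The expectation therefore rests on compound 1 alone and carries a wide range. Compound 3 is expected at about 3000 nM, with a range from 700 nM to 15000 nM. That estimate corresponds to a step of a 1.8-fold higher number from compound 1 to compound 3 (0.25 log units; within the scatter).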

Compound 3, concentration for 50% growth inhibition: 910 nM
For compound 3 the middle estimate is 3.3-fold (0.52 log units) above the measured one; the measured number falls inside the stated range.
By their numbers in this assay, from the lowest: compounds 3, 1 and 2 (each within the scatter of the next).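

At this aromatic carbon between two ring nitrogen atoms, replacing cyclopentylamino with phenoxy gives a 1.9-fold lower number from compound 1 to compound 3 (0.27 log units; within the scatter) in this assay, so the two groups cannot be told apart on this read-out. Within the data shown here, this is the first look at this position, and it shows that growth inhibition in this range does not depend on keeping cyclopentylamino there: a five-membered non-aromatic ring of carbon only can give way to a six-membered aromatic ring, the linking nitrogen to an oxygen, and 1 hydrogen-bond donor to 0 hydrogen-bond donors, all in a single change, with no difference beyond the scatter. No measurement on hand explains why the two groups read alike, and nothing here tells whether their separate features matter or offset one another.

Since ring and linking atom change together, the pair cannot say which of them matters, and phenylamino, which joins the same aromatic ring through a nitrogen, would pull the two apart. Going by these compounds, it also remains open how this position would respond to a much smaller group such as methoxy, or to a chain ending in a carboxylic acid.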